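Working notes: groups on the amide-type nitrogen, growth inhibition

The compounds below may be only part of what the source reports. "The series", "measured", "known", "first", "only" and "open" are said of these compounds alone.

Measured compounds:
compound 1 `CC1=CC[C@H](C(C)(C)NC(=S)NN)CC1` — 41900 nM
compound 2 `CC1=CC[C@H](C(C)(C)NC(=S)N/N=C/c2ccc(O)cc2)CC1` — limit, > 100000 nM
compound 3 `CC1=CC[C@H](C(C)(C)NC(=S)N/N=C/c2ccccc2Cl)CC1` — 15100 nM

All numbers come from a functional assay on OVCAR-3 cells (Homo sapiens) for inhibition, read by sulforhodamine B assay, with a stated time of 48 h; a higher number here means a weaker inhibitor of growth, a lower number a stronger inhibitor of growth. Compound 1 gives 41900 nM, the highest of the two numbers in the set. Compound 3 gives 15100 nM, a lower number than compound 1. Compound 2 reaches only the limit of this assay, > 100000 nM. Within the data shown here, the single step between compounds that differ in one place is an at least 6.6-fold lower number from compound 2 to compound 3 (0.82 log units; beyond the scatter): the ring on the carbon with a double bond to nitrogen can move the number from the limit of > 100000 nM in this assay, at which 1 of the 3 values shown sits, down to the region below compound 1.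

Compound 4 `CC1=CC[C@H](C(C)(C)NC(=S)N/N=C/c2ccc[nH]2)CC1` differs from compound 1 by a group of 7 heavy atoms (5 carbon, 2 nitrogen; one five-membered aromatic ring with 1 hetero atom) in place of one nitrogen atom, on an amide-type nitrogen. Among the measured compounds shown here, no measured step pairs the amino of compound 1 against a ring on that carbon, so the direction is open; the two measured ring compounds bracket compound 1 from both sides, one at the limit and one lower. The expectation is therefore a step of no clear direction in this assay, with a wide range covering both outcomes. Compound 4 is estimated at 35000 nM, between 9000 nM and 100000 nM, which means an expected step of a 1.2-fold lower number from compound 1 to compound 4 (0.08 log units; within the scatter).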

Compound 4, concentration for 50% growth inhibition: 33500 nM
Estimate against measurement, compound 4: 1.0-fold (0.02 log units) above; low and high end bracket the measured number.
By their numbers in this assay, from the lowest: compound 3; then compounds 4 and 1 (each within the scatter of the next). At a limit, above all of these: compound 2.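

In this assay, a group of 7 heavy atoms carrying 1H-pyrrol-2-yl in place of the amino on the amide-type nitrogen gives a 1.3-fold lower number from compound 1 to compound 4 (0.10 log units; within the scatter), so this first direct pairing of the amino with a ring-bearing group leaves the two compounds within the scatter of each other. The ring still matters among the ring-bearing compounds, since a 2.2-fold higher number from compound 3 to compound 4 (0.35 log units; beyond the scatter) is a modest step beyond the scatter that leaves 2-chlorophenyl with the lowest number of the compounds shown. The remaining step, an at least 2.9-fold lower number from compound 2 to compound 4 (0.47 log units; beyond the scatter), is only a bound, as the value of compound 2 is a limit: the limit of > 100000 nM in this assay, at which 1 of the 4 values shown sits.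

The compounds shown cannot separate the effect of the chlorine from that of its place on the ring, or from the loss of the hydroxyl, and plain phenyl and 4-chlorophenyl on the carbon with a double bond to nitrogen would be the direct tests. From the compounds shown here alone, it also remains open whether a methyl on the ring nitrogen of 1H-pyrrol-2-yl, or a furan-2-yl or pyridin-2-yl ring in its place, would keep the number within the scatter of compound 4.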